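A few compounds are considered here, and "the series" means these few. Any claim that something is new, unique, unknown or untested is made for them only; others in the source may bear on it.

Going by the values given here, compound 1 `CC(=O)Oc1ccc(/C=C/C(=O)OCCSc2nc(-c3ccc(S(C)(=O)=O)cc3)n(-c3ccc(F)cc3)n2)cc1OC(C)=O` is one of two compounds measured in a functional assay on B16-F10 cells (Mus musculus) for antiproliferative activity, read by MTT assay, with a stated time of 72 h (on this read-out higher numbers stand for weaker inhibition and lower numbers for stronger inhibition), and compound 1 gives 14200 nM. Among the compounds with values here, its companion, compound 2 `CC(=O)Oc1ccc(/C=C/C(=O)OCCSc2nc(-c3ccc(S(N)(=O)=O)cc3)n(-c3ccc(F)cc3)n2)cc1OC(C)=O`, gives 11000 nM in this assay; the only step measured so far, a 1.3-fold lower number from compound 1 to compound 2 (0.11 log units; within the scatter), places compound 1 as the higher of the two numbers, but within the scatter of compound 2. Compound 3 `COc1cc(/C=C/C(=O)OCCSc2nc(-c3ccc(S(C)(=O)=O)cc3)n(-c3ccc(F)cc3)n2)ccc1OC(C)=O` has not yet been measured. It differs from compound 1 by methyl in place of acetyl on an oxygen on an aromatic ring, an exchange that the step from compound 1 to compound 2, which changed a group on the sulfonyl sulfur, does not touch. Nothing measured here bears on a change at an oxygen on an aromatic ring, so no direction can be read from the data. The expectation for compound 3 is therefore a number close to that of compound 1, with a step of a 1.2-fold lower number from compound 1 to compound 3 (0.07 log units; within the scatter) that is expected to stay within the scatter. On that basis compound 3 is estimated at 12000 nM in this assay, within a range from 4000 nM to 40000 nM.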

Compound 3, half-maximal inhibitory concentration: 11200 nM
Beside the measured number, compound 3's estimate is 1.1-fold (0.03 log units) above it, and the stated range covers the measured number.
By their numbers in this assay, from the lowest: compounds 2, 3 and 1 (each within the scatter of the next).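

In this assay, going by these compounds alone, the exchange of acetoxy to methoxy gives the first reading of a change on an oxygen on an aromatic ring (a 1.3-fold lower number from compound 1 to compound 3 (0.10 log units; within the scatter)), so compound 1 and compound 3 cannot be told apart at this level of activity. In this one pair, acetyl, with its 3 heavy atoms and 1 hydrogen-bond acceptor, gives way to methyl, with 1 heavy atom and no acceptor, and the number stays within the scatter, while the other acetoxy group of compound 1 remains in place in compound 3. The change at this oxygen thus joins the change on the sulfonyl sulfur as a second single exchange that leaves the number within the scatter, and nothing available bears on why this should be so.

The compounds shown leave open how a free hydroxy group or a longer ethoxy chain on this oxygen would read, and whether the same exchange at the other acetoxy group would also stay within the scatter. They also leave open whether amino in place of methyl on the sulfonyl sulfur would read the same alongside the methoxy group of compound 3.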